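One Methoxy Fewer: Expecting the Step in Cell Killing

This account rests on a few compounds, and the source may have more. Where it says the series, first, only, none or still open, it means among the compounds named here.

Measured compounds:
compound 1 `COc1cc(-c2cc(/C=C/C(=O)c3ccc(N)cc3)[nH]n2)cc(OC)c1OC` gives -66%
compound 2 `COc1ccc(-c2cc(/C=C/C(=O)c3ccc(N)cc3)[nH]n2)cc1OC` gives -81%
compound 3 `COc1cc(C(=O)/C=C/c2cc(-c3cc(OC)c(OC)c(OC)c3)n[nH]2)cc(OC)c1OC` gives -72%

All three compounds were tested in a functional assay on OVCAR-5 cells (Homo sapiens) for cytotoxicity, read by sulforhodamine B assay, with a stated time of 48 h, tested at 100 uM; a higher number here means a weaker effect of the compound at the concentration tested, a lower number a stronger effect. Compound 1 and compound 2 differ in one place only, (hydrogen in place of methoxy on an aromatic carbon), and this change gave a number 15 percentage points lower from compound 1 to compound 2 (beyond the scatter). Compound 3 shares with compound 1 the same three methoxy groups on a six-membered carbon ring, but the two cores are built differently, and the difference between them is not broken down here. In this assay compound 3 gives a value within the scatter of that of compound 1, so no order between them can be claimed, and its value lies within the scatter of that of compound 2 as well.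

Compound 4 `COc1ccc(-c2cc(/C=C/C(=O)c3cc(OC)c(OC)c(OC)c3)[nH]n2)cc1OC` is not yet measured. It differs from compound 3 by hydrogen in place of methoxy on an aromatic carbon, and the surroundings of the place are described in the same words as for the change from compound 1 to compound 2, so it is the same change made on the other core. Going by the values given here, with only one measured example of this change, the expectation rests on that single step. The step expected here is a number 13 percentage points lower from compound 3 to compound 4 (beyond the scatter), because the measured step of a number 15 percentage points lower from compound 1 to compound 2 (beyond the scatter) went in the stronger direction by a modest amount. Starting from compound 3, compound 4 is therefore estimated to give -85%, with a plausible range from -100% to -65%.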

Compound 4, a percentage reported as activity, at one concentration (the size of the read-out at that concentration, not a potency): -70%
Estimate against measurement, compound 4: 15 percentage points below, within the range that was stated.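

In this assay, the exchange of a methoxy for hydrogen gave a number 2 percentage points higher from compound 3 to compound 4 (within the scatter), so on this core the change cannot be told apart from no change at all. The same exchange therefore did not behave alike on the two cores, and the gap between the two results is larger than chance scatter would readily explain: the same change on two cores in this assay, a number 15 percentage points lower (beyond the scatter) from compound 1 to compound 2 and a number 2 percentage points higher (within the scatter) from compound 3 to compound 4, 17 percentage points apart, beyond the scatter of two such steps This shows that the step seen on the core of compound 1 cannot simply be added to another core in this series, but it does not show why the cores respond differently, and one example on each core gives no rule for any further core.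

All of these readings come from a single concentration, so they describe the size of the effect at that concentration and say nothing about potency, which would need a full concentration series. Going by these compounds, it also remains open how other groups would behave at this same place on each core, for example a hydroxyl or an ethoxy group, and whether either would separate the two cores as clearly as this exchange did.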